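From 4-methylphenyl to 2-fluorophenyl on the shared core

A few compounds are considered here, and "the series" means these few. Any claim that something is new, unique, unknown or untested is made for them only; others in the source may bear on it.

Values measured in a functional assay on SW 1116 cells (Homo sapiens) for antiproliferative activity, read by MTT assay, with a stated time of 24 h (a higher number here means a weaker inhibitor, a lower number a stronger inhibitor), follow.
compound 1 `O=[N+]([O-])c1ccc(CSc2nnc(-c3ccc4c(c3)OCCO4)n2-c2ccccc2)cc1` gives 13800 nM
compound 2 `Clc1ccccc1CSc1nnc(-c2ccc3c(c2)OCCO3)n1-c1ccccc1` gives 9670 nM
compound 3 `Cc1ccc(CSc2nnc(-c3ccc4c(c3)OCCO4)n2-c2ccccc2)cc1` gives 16200 nM

Compound 3 cannot be told apart from the other two on these numbers. The gaps are a 1.2-fold higher number from compound 1 to compound 3 (0.07 log units; within the scatter) and a 1.7-fold higher number from compound 2 to compound 3 (0.22 log units; within the scatter) with neither beyond the scatter.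

The next compound is compound 4 `Fc1ccccc1CSc1nnc(-c2ccc3c(c2)OCCO3)n1-c1ccccc1` with 2-fluorophenyl in place of 4-methylphenyl on a saturated chain carbon bound to a sulfur. Three groups have been measured at this place, and the remaining gap among them is also small (a 1.4-fold lower number from compound 1 to compound 2 (0.15 log units; within the scatter)). No step beyond the scatter is therefore expected in this assay for this change. The closest comparison by name is compound 2 with 2-chlorophenyl, which gives 9670 nM so the estimate leans slightly towards that value. Within the data shown here, the expected change is a 1.4-fold lower number from compound 3 to compound 4 (0.13 log units; within the scatter) and no larger step is anticipated. The estimated value for compound 4 is 12000 nM with an expected range below (7000 nM to 20000 nM).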

Compound 4, half-maximal inhibitory concentration: 13600 nM
The estimate for compound 4 lay 1.1-fold (0.05 log units) below the measured number, and the stated range covers the measured number.
By their numbers in this assay, from the lowest: compounds 2, 4, 1 and 3 (each within the scatter of the next).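

In this assay, the fourth group at this place, on a saturated chain carbon bound to a sulfur, still produces no step beyond the scatter: a 1.2-fold lower number from compound 3 to compound 4 (0.08 log units; within the scatter), a 1.0-fold lower number from compound 1 to compound 4 (0.01 log units; within the scatter) and a 1.4-fold higher number from compound 2 to compound 4 (0.15 log units; within the scatter). Among these compounds, that last step, fluoro in place of chloro on an aromatic carbon, is the first to exchange a single atom, and even this pair cannot be told apart, so all four groups now read alike. Nothing measured alongside these numbers offers a reason for this sameness.

As far as these compounds go, all four groups are substituted phenyl rings, so it stays open whether a different kind of group here, such as a carboxylic acid or an amine on a longer chain, would give a step beyond the scatter. The compounds shown also leave open what a change elsewhere on the shared core would do.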